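The source may hold more compounds than are shown below. What is called first, only, known or untested is meant among the compounds shown, and "the series" means these compounds.

Measured in a functional assay on HepG2 cells (Homo sapiens) for antiproliferative activity, read by MTT assay, with a stated time of 96 h; a higher number here means a weaker inhibitor of growth, a lower number a stronger inhibitor of growth:
- compound 1 `Cc1cc(-c2ccc(F)cc2)n(Cc2ccc(C(=O)NO)cc2)n1`: 3630 nM
- compound 2 `Cc1ccc(-c2cc(C)nn2Cc2ccc(C(=O)NO)cc2)cc1`: 13300 nM
- compound 3 `O=C(CCNC(=O)c1cc(-c2ccc(F)cc2)[nH]n1)NO`: 76000 nM

Compound 3 has the highest number of the three. Compound 4 `O=C(CCCCCCNC(=O)c1cc(-c2ccc(F)cc2)[nH]n1)NO` differs from it in one place: 4-(hydroxycarbamoyl)butyl in place of hydroxycarbamoyl on a saturated chain carbon, two bonds along the chain from an amide-type nitrogen. Here 4-(hydroxycarbamoyl)butyl stands in place of hydroxycarbamoyl on a saturated chain carbon, two bonds along the chain from an amide-type nitrogen.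

For the measured compounds named here, no measured step alters this chain. The only one, a 3.7-fold higher number from compound 1 to compound 2 (0.56 log units; beyond the scatter), is a methyl in place of fluoro on an aromatic carbon, and it bears only weakly on this change. A large step to a lower number in this assay is nevertheless expected, on the thin ground that compound 3 at 76000 nM lies far above compound 2 at 13300 nM. The expected step is a 15-fold lower number from compound 3 to compound 4 (1.18 log units; beyond the scatter). The estimate for compound 4 is 5000 nM, within an expected range from 1200 nM to 20000 nM.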

Compound 4, concentration for 50% growth inhibition: 23200 nM
Compound 4: middle estimate off by 4.6-fold (0.67 log units), on the low side; the measured number lies above the stated range.
By their numbers in this assay, from the lowest: compound 1; then compounds 2 and 4 (each within the scatter of the next); then compound 3.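

Lengthening the chain at this position gives a 3.3-fold lower number from compound 3 to compound 4 (0.52 log units; beyond the scatter) in this assay and is the first measured change to this chain, since the earlier step touched only an aromatic carbon. It shows that 4-(hydroxycarbamoyl)butyl in place of hydroxycarbamoyl at this place lowers the number only modestly. Nothing available explains this step.

From the compounds shown here alone, it remains open whether a longer chain would lower the number further. Going by these compounds, it is also open how a carboxylic acid or an amine at the end of the chain would compare with the hydroxycarbamoyl group.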